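The source may hold more compounds than are shown below. What is called first, only, known or untested is meant among the compounds shown, and "the series" means these compounds.

Compound 1 `Nc1nc2ccccn2c1-c1ccc(O)cc1` carries a hydroxyphenyl on the shared core. In an assay on isolated protein for inhibition of ubiquitin carboxyl-terminal hydrolase 47 (Homo sapiens) (on this read-out lower numbers stand for stronger inhibition and higher numbers for weaker inhibition), compound 1 gives > 100000 nM, a limit of the assay. Compound 2 `Nc1nc2cc(C(F)(F)F)ccn2c1-c1ccc(O)cc1` adds a trifluoromethyl to that core. In this assay compound 2 gives > 100000 nM, again a limit. The step that the two limits leave unreadable from compound 1 to compound 2 cannot be sized due to the limit of > 100000 nM in this assay, at which 2 of the 2 values shown sit. Compound 3 `Cc1ccn2c(-c3ccc(O)cc3)c(N)nc2c1` differs from compound 2 by methyl in place of trifluoromethyl on an aromatic carbon. For the measured compounds named here, the only measured step that bears on this change rests on two limits, so no direction and no size can be read from it. Compound 3 is therefore expected to remain at the limit in this assay, with an estimate of 150000 nM within 40000 nM to 600000 nM. The expected step is a step that the limit leaves unreadable from compound 2 to compound 3.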

Compound 3, half-maximal inhibitory concentration: > 100000 nM
Compound 3 was reported as a limit; the forecaster's own chance of this, stated with the estimate: 80%; the middle value is on the limit's open side.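

For the compounds shown here, no step to compound 3 from compound 1 or compound 2 can be read in this assay: the limit of > 100000 nM in this assay, at which 3 of the 3 values shown sit. The compounds shown leave open whether any group on the shared core gives a measurable value in this assay.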